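Swapping a pyridine ring for a pyridylmethyl arm

The compounds below may be only part of what the source reports. "The series", "measured", "known", "first", "only" and "open" are said of these compounds alone.

Of the compounds shown here, two have been measured so far in an assay on isolated protein for inhibition of methionine--tRNA ligase, cytoplasmic (Homo sapiens); a higher number here means a weaker inhibitor, a lower number a stronger inhibitor. Compound 1 `O=C(O)c1cc(-c2ccc(-c3ccc(Cl)cc3Cl)cc2)n(-c2cccnc2)n1` gives 47000 nM in this assay, the higher of the two numbers. Compound 2 `O=C(O)c1cc(-c2ccc(-c3ccc(F)cc3)cc2)n(-c2ccc(Cl)cc2Cl)n1` gives 41300 nM in this assay, and the gap between compound 1 and compound 2 lies within the usual scatter, so the two cannot be told apart. Both are weak inhibitors.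

Compound 3 `O=C(O)c1cc(-c2ccc(-c3ccc(Cl)cc3Cl)cc2)n(Cc2cccnc2)n1` has not been measured. It differs from compound 1 in one place: (pyridin-3-yl)methyl in place of pyridin-3-yl on an aromatic nitrogen. The pyridine ring is kept, but it now hangs from the five-membered aromatic ring through a single carbon rather than being attached directly. Going by the values given here, no measured pair shows what such an insertion does here, so there is no step to lean on; the carboxylic acid and the chlorinated biphenyl part remain unchanged.

With no guide, the expectation is a step from compound 1 to compound 3 of a 1.2-fold lower number from compound 1 to compound 3 (0.07 log units; within the scatter), likely within the scatter, in no certain direction. Compound 3 is therefore estimated at 40000 nM in this assay, with a range from 13000 nM to 120000 nM.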

Compound 3, half-maximal inhibitory concentration: > 100000 nM
Compound 3: no number, only a limit; the forecaster's own chance of this, stated with the estimate: 20%; middle value at least 2.5-fold (0.39 log units) away from the limit.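

Replacing pyridin-3-yl with (pyridin-3-yl)methyl on the aromatic nitrogen is not a neutral change: in this assay it gives an at least 2.1-fold higher number from compound 1 to compound 3 (0.32 log units; beyond the scatter). Going by these compounds alone, for compound 3 the read-out is a limit of the assay and not a number: the limit of > 100000 nM in this assay, at which 1 of the 3 values shown sits. This is the first direct reading of this position, since compound 1 and compound 2 differ in more than one place and could not show what a change here alone does; among the two arrangements of the same pyridine ring, direct attachment gives the lower number, though compound 1 is itself a weak inhibitor.

The compounds shown do not tell whether the added carbon itself or the new placement of the pyridine ring lies behind this step, nor how far the step extends. A longer chain on this nitrogen, or an amine on the ring carried there, could separate these readings, and an amide in place of the carboxylic acid remains untested ground in the series shown here.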